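A few compounds are considered here, and "the series" means these few. Any claim that something is new, unique, unknown or untested is made for them only; others in the source may bear on it.

Measured so far:
compound 1, `CCCC(=O)c1ccc(OCCCCOc2cccc(C(=O)O)c2C)c(C)c1O`, 52 nM
compound 2, `CCC(=O)c1ccc(OCCCCOc2cccc(C(=O)O)c2C)c(C)c1O`, 62 nM
compound 3, `Cc1cc(C(=O)O)ccc1OCCCCOc1ccc(C(=O)C(C)C)c(O)c1C`, 234 nM

All three were tested in an assay on HEK293 cells for positive allosteric modulation of metabotropic glutamate receptor 2 (Rattus norvegicus), read by thallium flux, with a stated time of 2.5 min; on this read-out lower numbers stand for an effect already at smaller amounts and higher numbers for an effect only at larger amounts of compound. Compound 1 and compound 2 share one core and differ only by hydrogen in place of methyl on a saturated chain carbon, two bonds along the chain from a carbonyl carbon; that change gave a 1.2-fold higher number from compound 1 to compound 2 (0.08 log units; within the scatter). Compound 3 has the same atoms as compound 1 joined differently, and the difference between the two cores is not broken down here; in this assay compound 3 gives 234 nM, the highest of the three numbers.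

Going by these compounds, compound 4, `CCC(=O)c1ccc(OCCCCOc2ccc(C(=O)O)cc2C)c(C)c1O`, is still untested. It differs from compound 3 by hydrogen in place of methyl on a saturated chain carbon bound to a carbonyl carbon and a saturated chain carbon. Among the compounds with values here, this is the same kind of change as the one from compound 1 to compound 2, but not the same: there the methyl sat on a saturated chain carbon two bonds along the chain from a carbonyl carbon, here it sits on a saturated chain carbon bound to a carbonyl carbon and a saturated chain carbon.

In this assay compound 4 is expected to give about 200 nM, with the likely range 90 nM to 450 nM, because a 1.2-fold higher number from compound 1 to compound 2 (0.08 log units; within the scatter) stayed within the scatter. From the value of compound 3, 234 nM, a step near a 1.2-fold lower number from compound 3 to compound 4 (0.07 log units; within the scatter) is therefore expected.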

Compound 4, half-maximal effective concentration: 82 nM
Compound 4: middle estimate off by 2.4-fold (0.39 log units), on the high side, outside the stated range (below it).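

In this assay, putting hydrogen in place of methyl on a saturated chain carbon bound to a carbonyl carbon and a saturated chain carbon, which turns isopropylcarbonyl into propanoyl, gave a 2.9-fold lower number from compound 3 to compound 4 (0.46 log units; beyond the scatter) and so made a real difference on this core. Set beside the earlier case, this kind of change did not carry over from one core to another as a single fixed step: the same change on two cores in this assay, a 1.2-fold higher number (0.08 log units; within the scatter) from compound 1 to compound 2 and a 2.9-fold lower number (0.46 log units; beyond the scatter) from compound 3 to compound 4, 3.4-fold (0.53 log units) apart, beyond the scatter of two such steps. Within the data shown here, this rests on only two pairs, and the methyl sits in a different place in each, so it does not show whether the core or the place of the methyl sets the gap, and it gives no rule for other cores.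

Going by these compounds, it remains open what the isopropylcarbonyl-to-propanoyl change would do on the core of compound 1, where the two effects could be told apart. On these data alone, it is also open how a cyclopropyl or a tert-butyl group in place of the isopropyl would behave on either core.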